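This account rests on a few compounds, and the source may have more. Where it says the series, first, only, none or still open, it means among the compounds named here.

Measured so far:
- compound 1 `CCN(CC)c1cc(NC(=O)NNc2cc(-c3ccc(F)cc3)c3cnn(C)c3n2)cc(Cl)n1` gives 29400 nM
- compound 2 `Cc1nn(C)c2nc(NNC(=O)Nc3cc(Cl)nc(Cl)c3)cc(-c3ccco3)c12` gives 69200 nM

Both numbers come from a functional assay on HCT-116 cells (Homo sapiens) for cytotoxicity, read by MTT assay, with a stated time of 48 h, in the presence of a further agent that is not named here; a higher number here means that more compound is needed for the effect, a lower number that less compound is needed. Of the two, compound 1 stands at the lower number, and the gap to compound 2 lies beyond the usual scatter, so compound 1 needs less material for the same effect than compound 2. Compound 2 differs from compound 1 in several places at once, so the two values together say nothing about any single change.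

Compound 3 `Cn1ncc2c(-c3ccc(F)cc3)cc(NNC(=O)Nc3cc(Cl)nc(Cl)c3)nc21` has not yet been measured. It differs from compound 1 in one place: chloro in place of diethylamino on an aromatic carbon. The chloro group that enters gives compound 3 the same dichloropyridine portion that compound 2 carries, while the rest of the shared core stays as in compound 1. Among the compounds with values here, no measured pair isolates this change, so the expectation rests on the spread between compound 1 and compound 2 and on the size of the group that leaves. A modest step toward a higher number in this assay is expected, though one that may fall within the scatter. For compound 3 the estimate is 45000 nM, with a range from 15000 nM to 130000 nM, which means an expected step of a 1.5-fold higher number from compound 1 to compound 3 (0.18 log units; within the scatter).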

Compound 3, half-maximal effective concentration: 8210 nM
Estimate against measurement, compound 3: 5.5-fold (0.74 log units) above; the whole stated range lies above it.
By their numbers in this assay, from the lowest: compound 3; then compound 1; then compound 2.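

Within the data shown here, for the first time, a single change can be read on its own: in this assay, chloro in place of diethylamino, on an aromatic carbon next to the ring nitrogen, gives a 3.6-fold lower number from compound 1 to compound 3 (0.55 log units; beyond the scatter). This position therefore does not depend on the larger group for the effect seen here, since replacing the 5 heavy atoms of diethylamino with a single chlorine lowers the amount of compound needed rather than raising it. Nothing available here explains why the number falls.

The compounds shown carry only these two groups at this position, so it remains open whether the lower number comes from the presence of chloro or from the loss of diethylamino, a question that a plain hydrogen, a methoxy group or the smaller dimethylamino group could help to settle. On these data alone, compound 2 carries the same chloro group but differs from compound 3 in more than one place, so it also remains open whether this step would hold with other groups elsewhere on the shared core.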